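Swapping the five-membered ring on the shared core

The source may hold more compounds than are shown below. What is called first, only, known or untested is meant among the compounds shown, and "the series" means these compounds.

Measured so far in a functional assay on CHO-K1 cells for antagonist activity at adenosine receptor A1 (Homo sapiens), read by a beta-galactosidase reporter and cAMP accumulation, with stated times of 15 min and 6 h; a higher number here means a weaker inhibitor, a lower number a stronger inhibitor:
compound 1 `Cc1ccc(-c2nc(N)c3cc(Cc4ccccc4)sc3n2)o1`: 298 nM
compound 2 `Cc1ccc(-c2nc(N)c3cc(CCc4ccccc4)sc3n2)o1`: 2780 nM
compound 3 `Cc1ccc(-c2nc(N)c3cc(Cc4ccccc4F)sc3n2)o1`: < 16 nM

Compound 1 holds the lowest of the two plain numbers in this assay. Its nearest neighbour is compound 2, reached by the step of a 9.3-fold higher number from compound 1 to compound 2 (0.97 log units; beyond the scatter). The value of compound 3 is a limit of the assay and not a number; compound 3 sits at the limit of < 16 nM in this assay, at which 1 of the 3 values shown sits.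

Compound 4 `Cc1nc(-c2nc(N)c3cc(Cc4ccccc4)sc3n2)cs1` differs from compound 1 in a single place: 2-methyl-1,3-thiazol-4-yl in place of 5-methylfuran-2-yl on an aromatic carbon. Going by the values given here, none of the measured steps touches this position. The step of a 9.3-fold higher number from compound 1 to compound 2 (0.97 log units; beyond the scatter), the step of an at least 18-fold lower number from compound 1 to compound 3 (1.27 log units; beyond the scatter) and the step of an at least 170-fold lower number from compound 2 to compound 3 (2.23 log units; beyond the scatter) all concern the saturated chain carbon and its aryl group on the other side of the shared core, so they give no direct guide to exchanging the five-membered ring. Compound 4 is therefore expected to stay close to compound 1, with a change a 1.3-fold higher number from compound 1 to compound 4 (0.13 log units; within the scatter) that is not expected to go beyond the scatter, although the uncertainty is wide. Compound 4 is estimated at 400 nM, with a range from 120 nM to 1500 nM.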

Compound 4, inhibition constant: 263 nM
For compound 4 the middle estimate is 1.5-fold (0.18 log units) above the measured one; measured number inside the range.
By their numbers in this assay, from the lowest: compounds 4 and 1 (each within the scatter of the next); then compound 2. At a limit, below all of these: compound 3.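

In this assay, the exchange of the five-membered ring gives the only reading shown for this position, the aromatic carbon between two ring nitrogen atoms: a 1.1-fold lower number from compound 1 to compound 4 (0.05 log units; within the scatter). With the rest of compound 1 unchanged, 5-methylfuran-2-yl and 2-methyl-1,3-thiazol-4-yl cannot be told apart in this assay, although the entering ring carries two hetero atoms in place of one, with nitrogen and sulfur in place of oxygen, whereas the changes on the other side of the shared core in compound 2 and compound 3 both went beyond the scatter. Nothing measured here offers a reason why these two rings read alike.

A single exchange between two methyl-bearing five-membered rings leaves open whether this position would accept a six-membered ring such as phenyl or pyridyl, a ring without its methyl group, or a simple amine. It also leaves open whether 2-methyl-1,3-thiazol-4-yl would give a similar reading alongside the 2-fluorophenyl group of compound 3, whose value is a limit and not a number.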